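The source may hold more compounds than are shown below. What is called first, only, known or untested is meant among the compounds shown, and "the series" means these compounds.

Measured so far:
compound 1 `Cc1ccc(-c2cn(-c3ccc(CN4CCN(C)CC4)cc3)nn2)cc1Nc1nccc(-c2cccnc2)n1` in a functional assay on HL-60 cells (Homo sapiens) for inhibition, read by MTT assay, with a stated time of 72 h; a higher number here means a weaker inhibitor, a lower number a stronger inhibitor: 6740 nM
compound 2 `CCN(CC)c1ccc(-n2cc(-c3ccc(C)c(Nc4nccc(-c5cccnc5)n4)c3)nn2)cc1` in this assay: 13600 nM

Within the data shown here, compound 2 gives the higher of these two numbers, yet its only neighbour is close: the one measured step, a 2.0-fold higher number from compound 1 to compound 2 (0.30 log units; within the scatter), lies within the scatter. Compound 3 `COc1ccc(-n2cc(-c3ccc(C)c(Nc4nccc(-c5cccnc5)n4)c3)nn2)cc1` differs from compound 2 by methoxy in place of diethylamino on an aromatic carbon. Among the measured compounds shown here, the same place was changed in that measured step without a shift beyond the scatter, but no measured compound carries methoxy there, so the step is an extrapolation. In this assay the expected outcome is no change beyond the scatter, a 1.4-fold lower number from compound 2 to compound 3 (0.13 log units; within the scatter). Compound 3 is therefore estimated at 10000 nM, expected between 3000 nM and 40000 nM.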

Compound 3, half-maximal inhibitory concentration: > 30000 nM
Compound 3: only a limit was reported (the forecaster's own chance of this, stated with the estimate: 10%); middle value at least 3.0-fold (0.47 log units) from the limit.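

In this assay compound 3 gives only a limit of the assay, not a number: the limit of > 30000 nM in this assay, at which 1 of the 3 values shown sits. Even so, this position responds to the change, with an at least 2.2-fold higher number from compound 2 to compound 3 (0.34 log units; beyond the scatter) when methoxy replaces diethylamino, and with an at least 4.4-fold higher number from compound 1 to compound 3 (0.64 log units; beyond the scatter) when methoxy replaces (4-methylpiperazin-1-yl)methyl. The step between compound 1 and compound 2 stayed within the scatter, so only methoxy shows that the group on this aromatic carbon can matter.

On these data alone, how far compound 3 lies past its limit stays open. So does whether a primary amine or a carboxylic acid here would group with compound 1 and compound 2 or with compound 3.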